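Replacing 4-bromophenyl with 3-chloro-4-fluorophenyl: working notes

The compounds below may be only part of what the source reports. "The series", "measured", "known", "first", "only" and "open" are said of these compounds alone.

Three measured compounds share one core and differ in the aromatic group on an amide-type nitrogen. In a functional assay on A549 cells (Homo sapiens) for cytotoxicity, read by MTT assay, with a stated time of 72 h (a higher number here means a weaker inhibitor, a lower number a stronger inhibitor), compound 1 `Cc1ccc(F)cc1NC(=O)CN1CCN(c2nnc(Cc3ccccc3)c3ccccc23)CC1` gives "not active" (no number reported) with no number reported. Compound 2 `COc1ccc(NC(=O)CN2CCN(c3nnc(Cc4ccccc4)c4ccccc34)CC2)cc1OC` likewise gives "not active" (no number reported) with no number reported. Compound 3 `O=C(CN1CCN(c2nnc(Cc3ccccc3)c3ccccc23)CC1)Nc1ccc(Br)cc1` gives 2000 nM and is the only one of the three with a number, so it cannot yet be ranked by size of step against a measured neighbour.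

Compound 4 `O=C(CN1CCN(c2nnc(Cc3ccccc3)c3ccccc23)CC1)Nc1ccc(F)c(Cl)c1` has 3-chloro-4-fluorophenyl in place of 4-bromophenyl on an amide-type nitrogen is the whole change. Going by the values given here, no measured pair isolates this change. With compound 1 at "not active" (no number reported) and compound 2 at "not active" (no number reported) in the same series, a shift toward weaker inhibition is the more likely direction, and a report without a number remains possible.

The expected step of a 1.8-fold higher number from compound 3 to compound 4 (0.24 log units; within the scatter) is small and toward weaker inhibition, with no clear separation from the scatter. For compound 4 the estimated value is 3500 nM with an expected range of 1000 nM to 12000 nM in this assay on this basis.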

Compound 4, half-maximal inhibitory concentration: "not active" (no number reported)
Nothing numeric was reported for compound 4, so the estimate cannot be set against anything.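

With compound 4 reported without a number in this assay and compound 3 at 2000 nM, no step can be read between compound 3 and compound 4. Only compound 3 carries a number, so the compounds shown leave open how the aromatic group on the amide-type nitrogen relates to cytotoxicity. No measured property bears on this result.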